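Sulfone-to-sulfonamide change at the aryl sulfonyl group

A few compounds are considered here, and "the series" means these few. Any claim that something is new, unique, unknown or untested is made for them only; others in the source may bear on it.

Three compounds of the series have numbers in an assay on isolated protein for inhibition of Nicotinamide phosphoribosyltransferase (Homo sapiens), read by mass spectrometry, with stated times of 15 min and 30 min; a lower number here means a stronger inhibitor, a higher number a weaker inhibitor. Compound 1 `O=C(NCc1ccc(S(=O)(=O)c2ccccc2)cc1)NCc1cccnc1` gives 19 nM in this assay. Compound 2 `O=C(NCc1ccc(S(=O)(=O)c2ccccc2)cc1)N1CCc2ccncc2C1` gives 310 nM in this assay. Compound 3 `O=C(NCc1ccc(S(=O)(=O)C2CCC(F)(F)CC2)cc1)N1Cc2ccncc2C1` gives 78 nM in this assay. Compound 3 stands second highest of the three: the nearest number is that of compound 2, which is higher by a gap beyond the scatter, and the furthest is that of compound 1, which is lower by a gap beyond the scatter. No pair of these compounds differs in only one place, so no single step in this assay has been measured.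

Compound 4 `O=C(NCc1ccc(S(=O)(=O)N2CCC[C@H](O)C2)cc1)N1Cc2ccncc2C1` has not yet been measured in this assay. It differs from compound 3 in one place: 3-hydroxypiperidin-1-yl in place of 4,4-difluorocyclohexyl on a sulfonyl sulfur. Going by the values given here, no measured step touches this part of the shared core, and the three numbers give no direct guide to the change. The expectation is a modest move toward a weaker inhibitor, a 1.5-fold higher number from compound 3 to compound 4 (0.19 log units; within the scatter), with a wide range on either side of the number for compound 3. For compound 4 the expected value in this assay is 120 nM, within a range from 30 nM to 500 nM.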

Compound 4, half-maximal inhibitory concentration: 770 nM
Compound 4: middle estimate off by 6.4-fold (0.81 log units), on the low side; measured number above the stated range.
By their numbers in this assay, from the lowest: compound 1; then compound 3; then compound 2; then compound 4.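

In this assay, going by these compounds alone, 3-hydroxypiperidin-1-yl in place of 4,4-difluorocyclohexyl on a sulfonyl sulfur gives a 9.9-fold higher number from compound 3 to compound 4 (0.99 log units; beyond the scatter), the first measured step at this position, and it shows that the number responds to the group held on the sulfonyl sulfur. The step does not change one feature alone: it turns the sulfone into a sulfonamide and brings in a hydroxyl group and a defined stereocentre, so the weaker inhibition belongs to the whole exchange and not to any one of these features. No measurement at hand bears on why the number rises.

The data at hand do not separate the sulfonamide link from the hydroxyl group in this step. Unsubstituted piperidin-1-yl on the sulfonyl sulfur would address the hydroxyl group, and 4-hydroxycyclohexyl on the sulfone would address the link. The opposite enantiomer of the 3-hydroxypiperidin-1-yl group would show whether the defined stereocentre matters at this position.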